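The source may hold more compounds than are shown below. What is called first, only, known or untested is meant among the compounds shown, and "the series" means these compounds.

Measured in a functional assay on HCT-116 cells (Homo sapiens) for inhibition, read by MTT assay, with a stated time of 72 h; a higher number here means a weaker inhibitor of growth, a lower number a stronger inhibitor of growth:
- Compound 1 `CNC(=O)/C=C/c1ccncc1-c1ccc2ccccc2c1`: 6550 nM
- Compound 2 `CC(C)[C@@H](NC(=O)/C=C/c1ccncc1-c1ccc2ccccc2c1)C(=O)O`: "not determined" (no result reported)

Compound 2 has no place on the scale: in this assay compound 2 stands at "not determined" (no result reported), so it offers no number from which to measure a step. Among the compounds with values here, the only number in the set belongs to compound 1, at 6550 nM.

The account now follows one structural change: dimethylamino in place of (1-carboxy-2-methylpropyl)amino on a carbonyl carbon. On a carbonyl carbon, dimethylamino stands in place of (1-carboxy-2-methylpropyl)amino, and this gives compound 3 `CN(C)C(=O)/C=C/c1ccncc1-c1ccc2ccccc2c1`.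

Within the data shown here, no step from compound 2 can be sized. Among the measured compounds shown here, the only anchor is compound 1 at 6550 nM, and compound 3 is expected to differ from that value by no more than the scatter, in either direction. In this assay the estimated value for compound 3 is 8000 nM, with an expected range from 3000 nM to 25000 nM.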

Compound 3, concentration for 50% growth inhibition: 4540 nM
Beside the measured number, compound 3's estimate is 1.8-fold (0.25 log units) above it; measured number inside the range.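

Within the data shown here, this result gives the first step at this position that can be sized: in this assay, methyl in place of hydrogen on the amide-type nitrogen gives a 1.4-fold lower number from compound 1 to compound 3 (0.16 log units; within the scatter), so the methylamino and dimethylamino amides cannot be told apart here. The step from compound 2 to compound 3 cannot be read, since compound 2 has no number in this assay. Nothing measured explains the result or says what this nitrogen contributes to growth inhibition.

The compounds shown leave open whether an ethyl or longer chain on this nitrogen, or a cyclic amine such as morpholine on the carbonyl carbon, would give a step beyond the scatter. They also leave open how the simple primary amide or a carboxylic acid on such a chain would read in this assay.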